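A furan gives way to 4-chlorophenyl

The source may hold more compounds than are shown below. What is called first, only, known or untested is meant among the compounds shown, and "the series" means these compounds.

Measured so far in a functional assay on DU-145 cells (Homo sapiens) for cytotoxicity, read by ELISA, with a stated time of 4 days; on this read-out higher numbers stand for weaker inhibition and lower numbers for stronger inhibition:
Compound 1 `Clc1ccc(-c2cc(-c3ccco3)cc(-c3ccc(Cl)s3)n2)cc1`: 14800 nM
Compound 2 `Clc1ccc(-c2cc(-c3ccco3)nc(-c3ccc(Cl)s3)c2)o1`: 27700 nM

Compound 2, at 27700 nM, stands within the scatter of compound 1, at 14800 nM, so the two numbers shown cannot be told apart. Compound 3 `Clc1ccc(-c2cc(-c3ccc(Cl)o3)cc(-c3ccc(Cl)s3)n2)cc1` has not yet been measured. It departs from compound 2 by carrying 4-chlorophenyl in place of furan-2-yl on an aromatic carbon, next to the ring nitrogen (4-chlorophenyl in place of furan-2-yl on an aromatic carbon). Within the data shown here, no measured pair shows the size of such a change. In this assay, therefore, no step beyond the scatter is expected, in either direction. This expectation rests only on the closeness of compound 1 at 14800 nM and compound 2 at 27700 nM. The expected change is a 1.5-fold lower number from compound 2 to compound 3 (0.19 log units; within the scatter). For compound 3 the estimated value is 18000 nM, with an expected range from 7000 nM to 45000 nM.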

Compound 3, half-maximal inhibitory concentration: 23000 nM
For compound 3 the middle estimate is 1.3-fold (0.11 log units) below the measured one; measured number inside the range.
By their numbers in this assay, from the lowest: compounds 1, 3 and 2 (each within the scatter of the next).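

In this assay, the position on an aromatic carbon next to the ring nitrogen now has a measured step: 4-chlorophenyl in place of furan-2-yl gives a 1.2-fold lower number from compound 2 to compound 3 (0.08 log units; within the scatter). The larger, all-carbon aromatic ring therefore cannot be told apart from furan-2-yl at this position in this comparison. A second single change, chloro in place of hydrogen on an aromatic carbon, gives a 1.6-fold higher number from compound 1 to compound 3 (0.19 log units; within the scatter), so this exchange also cannot be told apart from the scatter. No measurement given here bears on the reason for either result.

The compounds shown leave open whether a primary amine or a carboxylic acid at this position would give a step beyond the scatter. They also leave open what would follow if the 5-chlorothiophen-2-yl group were replaced by a morpholine ring.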